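The source may report more compounds than this note shows. Statements on the series, on what has been measured and on what is new or still open speak of the compounds shown alone.

Notes on the series. Compound 1 `COC(=O)N[C@H]1Cc2ccc(NC(=O)c3ccccc3-c3ccc(C(F)(F)F)cc3)cc2C1` in an assay on isolated protein for inhibition of microsomal triglyceride transfer protein large subunit (Homo sapiens) (on this read-out lower numbers stand for stronger inhibition and higher numbers for weaker inhibition), gives 68 nM. Compound 2 `COC(=O)N[C@H]1Cc2ccc(NC(=O)c3cc(C)ccc3-c3ccc(C(F)(F)F)cc3)cc2C1` differs from compound 1 by methyl in place of hydrogen on an aromatic carbon; in this assay compound 2 gives 170 nM, and the step is a 2.5-fold higher number from compound 1 to compound 2 (0.40 log units; beyond the scatter). Compound 3 `COC(=O)NC1CCc2ccc(NC(=O)c3cccc(C)c3-c3ccc(C(F)(F)F)cc3)cc2CC1` sits on a core whose difference from the core of compound 1 is not broken down here. In this assay compound 3 gives 20 nM, the lowest of the three measured numbers. Compound 4 `COC(=O)NC1CCc2ccc(NC(=O)c3cc(C)cc(C)c3-c3ccc(C(F)(F)F)cc3)cc2CC1` arises from compound 3 by methyl in place of hydrogen on an aromatic carbon; the entering methyl here is also meta to a methyl group, so this is the same kind of change as that from compound 1 to compound 2, not the same. The step is expected to be a 2.0-fold higher number from compound 3 to compound 4 (0.30 log units; within the scatter), resting on a 2.5-fold higher number from compound 1 to compound 2 (0.40 log units; beyond the scatter). Compound 4 is therefore estimated at 40 nM, expected between 18 nM and 90 nM.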

Compound 4, half-maximal inhibitory concentration: 20 nM
The estimate for compound 4 lay 2.0-fold (0.30 log units) above the measured number; the range from low to high includes it.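

Adding the methyl gives no change at the digits printed from compound 3 to compound 4 (within the scatter). Set beside the earlier step, the two results cannot be told apart, so the change carries from one core to the other without a measurable difference: the same change on two cores in this assay, a 2.5-fold higher number (0.40 log units; beyond the scatter) from compound 1 to compound 2 and no change at the digits printed (within the scatter) from compound 3 to compound 4, 2.5-fold (0.40 log units) apart, within the scatter of two such steps. This rests on one pair per core, and in compound 4 the entering methyl is also meta to a methyl group, so it does not show that the step is constant across the series or that it would hold on a third core.

As far as these compounds go, whether a methoxy group, a chlorine atom or a nitrile on the same aromatic carbon would follow methyl remains open. So does the size of the step with an amine or a carboxylic acid in place of the trifluoromethyl.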